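The source may report more compounds than this note shows. Statements on the series, on what has been measured and on what is new or still open speak of the compounds shown alone.

Measured so far:
- compound 1, `COc1ccc(/C=C/S(=O)(=O)Nc2ccc(OC)c(F)c2)cc1`: 1000 nM
- compound 2, `COC(=O)CNc1cc(NS(=O)(=O)/C=C/c2c(OC)cc(OC)cc2OC)ccc1OC`: 350 nM

Both compounds were tested in a functional assay on K562 cells (Homo sapiens) for cytotoxicity, read by trypan blue exclusion, with a stated time of 96 h; on this read-out higher numbers stand for weaker inhibition and lower numbers for stronger inhibition. Of the two numbers, compound 2 gives the lowest; its nearest neighbour is compound 1, whose number is higher by a gap beyond the usual scatter, so on these two values compound 2 is the stronger inhibitor.

Compound 3, `COc1cc(OC)c(/C=C/S(=O)(=O)Nc2ccc(OC)c(NC(C(=O)O)c3ccccc3)c2)c(OC)c1`, has not yet been measured. Compared with compound 2 it differs in one place: carboxy(phenyl)methyl in place of (methoxycarbonyl)methyl on a nitrogen on an aromatic ring. Among the measured compounds shown here, no measured pair shows this change, so its effect is unknown from the data at hand.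

For compound 3 the expectation is a modest step towards a higher number than compound 2, that is a somewhat weaker inhibition, though a result within the scatter of compound 2 would not be surprising; the expected step is a 1.9-fold higher number from compound 2 to compound 3 (0.27 log units; within the scatter). The estimate for compound 3 in this assay is 650 nM, with a range from 180 nM to 2500 nM.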

Compound 3, half-maximal inhibitory concentration: 300 nM
Beside the measured number, compound 3's estimate is 2.2-fold (0.34 log units) above it, and the stated range covers the measured number.
By their numbers in this assay, from the lowest: compounds 3 and 2 (each within the scatter of the next); then compound 1.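

In this assay, replacing the group on a nitrogen on an aromatic ring gives a 1.2-fold lower number from compound 2 to compound 3 (0.07 log units; within the scatter), so this read-out does not separate the two groups. The earlier compounds shown here gave no view of any change at this position; this step shows that the number can stay within the scatter when a group of 5 heavy atoms with no ring gives way to one of 10 heavy atoms carrying a six-membered aromatic ring and a hydrogen-bond donor. Nothing available explains this result.

As far as these compounds go, the step alters the carboxy end and adds the aromatic ring together, so the share of each remains unknown. A carboxymethyl group, which has the carboxylic acid without the phenyl ring, or a benzyl group, which has the phenyl ring without the carboxylic acid, would be needed to tell them apart.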